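Dimethylsulfamoyl added to the pyridyl alkyne of compound 1

The source may report more compounds than this note shows. Statements on the series, on what has been measured and on what is new or still open speak of the compounds shown alone.

Among the compounds with values here, compound 1 `Cc1ncccc1C#Cc1cc(Cl)ccc1OCC(=O)O` stands second highest of the three numbers so far in an assay on CHO cells for displacement of a labelled ligand from prostaglandin D2 receptor 2 (Homo sapiens), read by scintillation counting (a lower number here means a stronger inhibitor, a higher number a weaker inhibitor), where compound 1 gives 143 nM. Its nearest neighbour is compound 3 `O=C(O)COc1ccc(Cl)cc1C#Cc1ccccc1Cl`, which in this assay gives 28 nM; the step is a 5.1-fold lower number from compound 1 to compound 3 (0.71 log units; beyond the scatter). The furthest is compound 2 `Cn1ccnc1C#Cc1cc(Cl)ccc1OCC(=O)O`, which in this assay gives 1470 nM; the step is a 10-fold higher number from compound 1 to compound 2 (1.01 log units; beyond the scatter). The remaining pair, a 53-fold lower number from compound 2 to compound 3 (1.72 log units; beyond the scatter), is the widest spread in the set. All three measured steps exchange the whole aryl group on the triple-bonded carbon.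

Compound 4 `Cc1ncc(S(=O)(=O)N(C)C)cc1C#Cc1cc(Cl)ccc1OCC(=O)O` keeps the 2-methylpyridin-3-yl of compound 1 and differs only in dimethylsulfamoyl in place of hydrogen on an aromatic carbon. Within the data shown here, no measured step adds a substituent to that ring while leaving the rest of the molecule untouched, so none of the three steps bears directly on this change. The aryl swaps a 10-fold higher number from compound 1 to compound 2 (1.01 log units; beyond the scatter) and a 5.1-fold lower number from compound 1 to compound 3 (0.71 log units; beyond the scatter) show that the group on the triple-bonded carbon matters, but they give no direction for a ring substituent. For compound 4 the expected step is therefore small, a 1.0-fold higher number from compound 1 to compound 4 (0.02 log units; within the scatter), and carries a wide range. The estimate for compound 4 in this assay is 150 nM, within 35 nM to 650 nM.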

Compound 4, inhibition constant: 41 nM
Compound 4: middle estimate off by 3.7-fold (0.56 log units), on the high side; the measured number falls inside the stated range.
By their numbers in this assay, from the lowest: compounds 3 and 4 (each within the scatter of the next); then compound 1; then compound 2.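

Within the data shown here, the step of a 3.5-fold lower number from compound 1 to compound 4 (0.54 log units; beyond the scatter) in this assay is the first that keeps the 2-methylpyridin-3-yl group on the triple-bonded carbon and changes only a substituent on that ring, whereas the earlier steps exchanged the whole aryl group. It shows that this aromatic carbon, two atoms from the ring nitrogen, meta to a large group and para to a methyl group, can carry dimethylsulfamoyl, with its 6 heavy atoms, and that the number falls rather than rises, so substitution here is a route to stronger inhibition in this pair. Nothing available here accounts for the size or direction of this step.

Going by these compounds, it remains open whether the step depends on the whole dimethylsulfamoyl group or on part of it, which a primary sulfonamide, a methylsulfonyl group or a morpholine-derived sulfonamide at the same carbon would help to separate. Also open, on these data alone, is whether the same substituent gives a step of similar size on the 2-chlorophenyl ring of compound 3, or whether a smaller group such as a nitrile does so on the pyridine ring.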